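This account rests on a few compounds, and the source may have more. Where it says the series, first, only, none or still open, it means among the compounds named here.

Measured compounds:
compound 1, `CN1CCN(c2ccc(S(=O)(=O)Oc3cccc(F)c3)cc2)C1=O`: > 100000 nM
compound 2, `CN1CCN(c2ccc(S(=O)(=O)Oc3cccc([N+](=O)[O-])c3)cc2)C1=O`: > 100000 nM
compound 3, `CN1CCN(c2ccc(S(=O)(=O)Oc3ccc(F)cc3)cc2)C1=O`: > 100000 nM

All three were tested in a functional assay on MCF7 cells (Homo sapiens) for antiproliferative activity, read by sulforhodamine B assay, with a stated time of 48 h; a lower number here means a stronger inhibitor, a higher number a weaker inhibitor. For compound 1 the figure > 100000 nM is a limit of the assay, not a number. For compound 2 the figure > 100000 nM is likewise a limit. For compound 3 the figure > 100000 nM is a limit as well. Compound 1 therefore stands nowhere on a readable scale; it sits at the limit together with the other two, as the limit of > 100000 nM in this assay, at which 3 of the 3 values shown sit, records.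

The steps a step that the two limits leave unreadable from compound 1 to compound 2 and a step that the two limits leave unreadable from compound 1 to compound 3 are thus of unknown size, since both ends of each rest on a limit.

Compound 4, `CCCN1CCN(c2ccc(S(=O)(=O)Oc3cccc(F)c3)cc2)C1=O`, differs from compound 1 by ethyl in place of hydrogen on a saturated chain carbon bound to an amide-type nitrogen in a ring. Neither measured step touches this part of the shared core: one exchanges nitro for fluoro on an aromatic carbon, the other exchanges the fluorophenyl on the oxygen. So no measured step bears on the change directly, and the only guidance is that every measured compound sits at the limit.

On that basis the step of a number no higher from compound 1 to compound 4 (the limit leaves the size open) is expected to show no change beyond the scatter. Compound 4 is expected to give 100000 nM in this assay, between 25000 nM and 400000 nM, most probably reported again only as a limit.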

Compound 4, half-maximal inhibitory concentration: 24000 nM
For compound 4 the middle estimate is 4.2-fold (0.62 log units) above the measured one; measured number below the stated range.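

In this assay, the change of methyl to propyl on the saturated chain carbon bound to an amide-type nitrogen in a ring gives an at least 4.1-fold lower number from compound 1 to compound 4 (0.61 log units; beyond the scatter), a step that can be read even though one of its ends rests on a limit, so the true size may be larger. The other changes shown, nitro in place of fluoro and 4-fluorophenyl in place of 3-fluorophenyl, could not be read, so this position is the only place among these compounds where a change is seen to alter the result. Compound 4 alone has left the limit, and the rest of the series remains there: the limit of > 100000 nM in this assay, at which 3 of the 4 values shown sit.

A single step cannot say whether the number keeps falling as the chain grows, or whether a butyl chain, a branched isopropyl group or a chain ending in an amine would go further than propyl. It also leaves open whether propyl at this position would bring the nitro compound or the 4-fluorophenyl compound off the limit in the same way, since that pairing appears nowhere here.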